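From 4-hydroxyphenyl to benzamidomethyl on a shared core

A few compounds are considered here, and "the series" means these few. Any claim that something is new, unique, unknown or untested is made for them only; others in the source may bear on it.

In a functional assay on A549 cells (Homo sapiens) for inhibition, read by MTT assay, with a stated time of 72 h (a lower number here means a stronger inhibitor, a higher number a weaker inhibitor), compound 1 `O=[N+]([O-])c1ccc(-c2nnc(SCCCN3CCN(c4nc5ccccc5o4)CC3)o2)cc1` gives 90800 nM, compound 2 `Clc1ccc(-c2nnc(SCCCN3CCN(c4nc5ccccc5o4)CC3)o2)cc1` gives 127000 nM and compound 3 `Oc1ccc(-c2nnc(SCCCN3CCN(c4nc5ccccc5o4)CC3)o2)cc1` gives 181000 nM. The measured steps are a 1.4-fold higher number from compound 1 to compound 2 (0.15 log units; within the scatter), a 2.0-fold higher number from compound 1 to compound 3 (0.30 log units; within the scatter) and a 1.4-fold higher number from compound 2 to compound 3 (0.15 log units; within the scatter), so compound 3 has no clear rank among the three. Compound 4 `O=C(NCc1nnc(SCCCN2CCN(c3nc4ccccc4o3)CC2)o1)c1ccccc1` carries benzamidomethyl in place of 4-hydroxyphenyl on an aromatic carbon. These steps bear on this change only loosely, since each exchanges one group on an aromatic carbon and none replaces the whole 4-hydroxyphenyl. No shift beyond the scatter is therefore expected, in either direction, and the expected step is a 1.2-fold lower number from compound 3 to compound 4 (0.08 log units; within the scatter). Compound 4 is estimated at 150000 nM, with an expected range from 60000 nM to 350000 nM.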

Compound 4, half-maximal inhibitory concentration: 102000 nM
Compound 4: middle estimate off by 1.5-fold (0.17 log units), on the high side; the measured number falls inside the stated range.
By their numbers in this assay, from the lowest: compounds 1, 4, 2 and 3 (each within the scatter of the next).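

In this assay the exchange of the whole 4-hydroxyphenyl for benzamidomethyl gives a 1.8-fold lower number from compound 3 to compound 4 (0.25 log units; within the scatter) and the exchanges of 4-chlorophenyl and 4-nitrophenyl for it give a 1.2-fold lower number from compound 2 to compound 4 (0.10 log units; within the scatter) and a 1.1-fold higher number from compound 1 to compound 4 (0.05 log units; within the scatter). Among these four compounds, then, replacing the entire group at this position, and not only the group carried on its phenyl ring, produces no shift beyond the scatter. No measurement at hand accounts for this result. From the compounds shown here alone, whether an amine, a carboxylic acid or a longer chain at this position would move the number beyond the scatter remains open.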